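Aryl substituent change: nitrile to ethynyl

The source may report more compounds than this note shows. Statements on the series, on what has been measured and on what is new or still open speak of the compounds shown alone.

Compound 1 `CC(=O)/C(=N\c1cccc(F)c1)NNc1ccccc1C(F)(F)F` gives 197 nM in an assay on isolated protein for binding affinity to corticotropin-releasing factor receptor 1 (Homo sapiens); a higher number here means a weaker inhibitor, a lower number a stronger inhibitor.
Compound 2 `CC(=O)/C(=N\c1cccc(C#N)c1)NNc1ccccc1C(F)(F)F` gives > 10000 nM.

For compound 2 the value in this assay is only a limit of the assay, not a number. Compound 3 `C#Cc1cccc(/N=C(/NNc2ccccc2C(F)(F)F)C(C)=O)c1` differs from compound 2 by ethynyl in place of cyano on an aromatic carbon. Among the measured compounds shown here, the only measured step nearby is an at least 50-fold higher number from compound 1 to compound 2 (1.70 log units; beyond the scatter), which ends at the limit of > 10000 nM in this assay, at which 1 of the 2 values shown sits; no step on the nitrile to ethynyl change itself has been measured. Because compound 2 rests at the limit of > 10000 nM in this assay, at which 1 of the 2 values shown sits, the direction of an at least 3.3-fold lower number from compound 2 to compound 3 (0.52 log units; beyond the scatter) is expected to be toward a lower number, but its size is poorly fixed. Compound 3 is estimated at 3000 nM, within 300 nM to 30000 nM.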

Compound 3, inhibition constant: 66 nM
For compound 3 the middle estimate is 45-fold (1.66 log units) above the measured one; measured number outside the range, below it.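

Ethynyl in place of cyano, on the aromatic carbon meta to a large group, gives in this assay an at least 150-fold lower number from compound 2 to compound 3 (2.18 log units; beyond the scatter). Compound 2 carries only a limit of the assay, not a number: the limit of > 10000 nM in this assay, at which 1 of the 3 values shown sits.
With ethynyl in place of fluoro there is a 3.0-fold lower number from compound 1 to compound 3 (0.47 log units; beyond the scatter), so a triple bond outside aromatic rings at this position does not by itself bring the loss seen with cyano, although the two groups match in heavy atoms and differ in hydrogen-bond acceptors.

On these data alone, whether that acceptor separates them stays open. So does how methoxy, chloro or a longer chain such as propynyl would read here.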